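This account rests on a few compounds, and the source may have more. Where it says the series, first, only, none or still open, it means among the compounds named here.

Measured so far in an assay on isolated protein for displacement of a labelled ligand from secreted frizzled-related protein 1 (Homo sapiens), read by fluorescence polarization, with a stated time of 30 min; a lower number here means a stronger inhibitor, a higher number a weaker inhibitor:
compound 1, `O=C(O)c1ccc(N2CCC(NS(=O)(=O)c3cc(S(=O)(=O)c4ccccc4)ccc3C(F)(F)F)CC2)cc1`, gives 120 nM
compound 2, `O=C(O)CCCC(=O)N1CCC(NS(=O)(=O)c2cc(S(=O)(=O)c3ccccc3)ccc2C(F)(F)F)CC1`, gives 500 nM

Of these two numbers compound 2 has the higher one, so it is the weaker inhibitor: the step of a 4.2-fold higher number from compound 1 to compound 2 (0.62 log units; beyond the scatter) was a modest weakening, beyond the scatter. Compound 3, `O=C([C@H]1CCNC1)N1CCC(NS(=O)(=O)c2cc(S(=O)(=O)c3ccccc3)ccc2C(F)(F)F)CC1`, is not yet measured. Its change from compound 2 is pyrrolidin-3-yl in place of 3-carboxypropyl on a carbonyl carbon. Among the compounds with values here, no measured step swaps an acid-bearing chain for a ring amine, so the only guide is the size of a 4.2-fold higher number from compound 1 to compound 2 (0.62 log units; beyond the scatter). On that basis a small step, a 1.6-fold higher number from compound 2 to compound 3 (0.20 log units; within the scatter), is expected for compound 3, possibly within the scatter. Compound 3 is estimated at 800 nM, with a range of 250 nM to 2500 nM.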

Compound 3, half-maximal inhibitory concentration: 40 nM
The estimate for compound 3 lay 20-fold (1.30 log units) above the measured number; the measured number lies below the stated range.
By their numbers in this assay, from the lowest: compound 3; then compound 1; then compound 2.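

In this assay, the group on this carbonyl carbon strongly affects the result: pyrrolidin-3-yl in place of 3-carboxypropyl gives a 13-fold lower number from compound 2 to compound 3 (1.10 log units; beyond the scatter). (Pyrrolidin-3-yl)carbonyl also outperforms 4-carboxyphenyl on the ring nitrogen, with a 3.0-fold lower number from compound 1 to compound 3 (0.48 log units; beyond the scatter), so a carboxylic acid is not required for strong inhibition here. Nothing available explains why this change strengthens inhibition.

The compounds shown do not separate the contribution of the ring from that of its nitrogen, which an open-chain amine such as 3-aminopropyl could test. They also leave open how the other stereoisomer of the pyrrolidin-3-yl group would compare.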